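Phenyl in place of 3,4-dimethoxyphenyl: working notes

The source may hold more compounds than are shown below. What is called first, only, known or untested is meant among the compounds shown, and "the series" means these compounds.

Going by the values given here, in a functional assay on THP-1 cells (Homo sapiens) for inhibition, read by sulforhodamine B assay, with a stated time of 48 h, tested at 50 uM (on this read-out higher numbers stand for more inhibition of growth at the one concentration tested and lower numbers for less inhibition of growth), compound 3 (`COc1ccc(/C=C/C(=O)/C=C/c2ccc(OCc3cn(CCOc4cc(=O)oc5ccccc45)nn3)c(OC)c2)cc1OC`) gives 90%, the highest of the three numbers so far. Compound 2 (`COc1cccc(/C=C/C(=O)/C=C/c2ccc(OCc3cn(CCOc4cc(=O)oc5ccccc45)nn3)c(OC)c2)c1`) gives 77% and compound 1 (`COc1cc(/C=C/C(=O)/C=C/c2cccs2)ccc1OCc1cn(CCOc2cc(=O)oc3ccccc23)nn1`) gives 76%. The step separating these two is a number 1 percentage points higher from compound 1 to compound 2 (within the scatter).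

Next is compound 4 (`COc1cc(/C=C/C(=O)/C=C/c2ccccc2)ccc1OCc1cn(CCOc2cc(=O)oc3ccccc23)nn1`), which differs from compound 3 as follows: phenyl in place of 3,4-dimethoxyphenyl on a double-bonded chain carbon bound to a double-bonded chain carbon. In words, this is phenyl in place of 3,4-dimethoxyphenyl on a double-bonded chain carbon bound to a double-bonded chain carbon.

Among the compounds with values here, two measured steps bear on this change. The closer is a number 13 percentage points higher from compound 2 to compound 3 (beyond the scatter), which comes with methoxy in place of hydrogen on an aromatic carbon. The other is a number 14 percentage points higher from compound 1 to compound 3 (beyond the scatter). Within the data shown here, both are modest, and no measured step removes all the methoxy groups at once, so the reverse direction is an inference. A modest fall beyond the scatter is expected in this assay. The expected step is a number 15 percentage points lower from compound 3 to compound 4 (beyond the scatter). For compound 4 the estimated value is 75%, with an expected range of 62% to 87%.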

Compound 4, percent growth inhibition at one concentration: 61%
Compound 4: the middle estimate sits 14 percentage points above what was measured; the measured number lies below the stated range.
By their numbers in this assay, from the lowest: compound 4; then compounds 1 and 2 (each within the scatter of the next); then compound 3.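

In this assay, the step to phenyl is larger than the earlier methoxy steps suggested: a number 29 percentage points lower from compound 3 to compound 4 (beyond the scatter). The single methoxy also counts, with a number 16 percentage points lower from compound 2 to compound 4 (beyond the scatter), so among these three compounds the number rises from phenyl through 3-methoxyphenyl to 3,4-dimethoxyphenyl, each step beyond the scatter. The thiophen-2-yl compound also stands clear of the phenyl compound, with a number 15 percentage points lower from compound 1 to compound 4 (beyond the scatter), so phenyl at this place on the double-bonded chain carbon gives the lowest number of the four, and nothing available explains this trend.

On these data alone, it remains open whether the rise belongs to methoxy itself or would also follow from ethoxy, hydroxy or a dimethylamino group on the same phenyl. The effect of a longer alkoxy chain or a carboxylic acid at this place is equally unsettled.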